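Nitro in place of benzyloxy on a urea ACAT inhibitor

This account rests on a few compounds, and the source may have more. Where it says the series, first, only, none or still open, it means among the compounds named here.

Of the compounds shown here, two share a urea core and have been measured in an assay on microsomes for inhibition of acyl-CoA:cholesterol acyltransferase (Oryctolagus cuniculus); a lower number here means a stronger inhibitor, a higher number a weaker inhibitor. Compound 1 `Cc1ccc(C2(CNC(=O)Nc3c(C(C)C)cccc3C(C)C)CCCC2)cc1` gives 25 nM. Compound 2 `CC(C)c1cccc(C(C)C)c1NC(=O)NCC1(c2cccc(OCc3ccccc3)c2)CCCC1` gives 30 nM in this assay, the higher of the two numbers, yet the two values lie within the scatter of each other, so nothing separates them.

Compound 3 `CC(C)c1cccc(C(C)C)c1NC(=O)NCC1(c2cccc([N+](=O)[O-])c2)CCCC1` is not yet measured. It differs from compound 2 in one place: nitro in place of benzyloxy on an aromatic carbon.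

Among the measured compounds shown here, no measured pair shows the effect of this change, so the expectation rests only on the two values above. Those show that the group on this ring can be exchanged without a visible shift, but both measured groups contain carbon only, and the nitro brings something different. A modest step toward a weaker inhibitor in this assay is expected, though a result inside the scatter cannot be excluded. For compound 3 the estimate in this assay is 70 nM, with a range from 20 nM to 250 nM, which is expected to mean a step of a 2.3-fold higher number from compound 2 to compound 3 (0.37 log units; beyond the scatter).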

Compound 3, half-maximal inhibitory concentration: 51 nM
Beside the measured number, compound 3's estimate is 1.4-fold (0.14 log units) above it, and the stated range covers the measured number.
By their numbers in this assay, from the lowest: compounds 1, 2 and 3 (each within the scatter of the next, the first and the last beyond it).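

In this assay, the nitro takes the place of the benzyloxy with a 1.7-fold higher number from compound 2 to compound 3 (0.23 log units; within the scatter) and the assay cannot separate the two, even though the group that leaves carries a six-membered aromatic ring and the group that enters has no ring. So this aromatic carbon accepts two very different groups without a shift that can be told from the scatter. The comparison with the third compound gives a 2.0-fold higher number from compound 1 to compound 3 (0.31 log units; beyond the scatter) as a modest step, but 3-nitrophenyl and 4-methylphenyl differ in both the group and the place it holds, and no separate measurement bears on the reason for any of these numbers.

From the compounds shown here alone, whether the same holds for an amine or a carboxylic acid on this aromatic carbon stays open, as does the effect of a longer chain in place of the benzyloxy. The compounds shown also cannot say whether the modest step comes from the group itself or from where it sits on the ring, since no pair here changes only one of the two.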